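Benzyl for Phenyl on the Carbamate Nitrogen: An Expected Step

The source may report more compounds than this note shows. Statements on the series, on what has been measured and on what is new or still open speak of the compounds shown alone.

Compound 1 `O=C(NCc1ccccc1)Oc1ccc(Cl)cc1C(=O)Nc1ccc(F)cc1`: 34200 nM
Compound 2 `O=C(Nc1ccccc1)Oc1ccc(Cl)cc1C(=O)Nc1ccc(F)cc1`: 3250 nM
Compound 3 `O=C(Nc1ccccc1)Oc1ccccc1C(=O)Nc1ccccc1`: 26800 nM

These three compounds were tested in an ADME assay on HepG2 cells (Homo sapiens), read by MTT assay, with a stated time of 72 h, in the presence of a further agent that is not named here; a higher number here means a weaker inhibitor, a lower number a stronger inhibitor. Compound 2 and compound 1 share a core and differ only by benzyl in place of phenyl on an amide-type nitrogen; that change gave an 11-fold higher number from compound 2 to compound 1 (1.02 log units; beyond the scatter). Compound 3 differs from compound 2 in its core, and the difference between the two cores is not broken down here. Compound 4 `O=C(NCc1ccccc1)Oc1ccccc1C(=O)Nc1ccccc1` has not yet been measured; it differs from compound 3 by benzyl in place of phenyl on an amide-type nitrogen, the same change in the same place as from compound 2 to compound 1. If that step carries over to this core, compound 4 is expected to give a 7.5-fold higher number from compound 3 to compound 4 (0.87 log units; beyond the scatter), resting on the step from compound 2 to compound 1 and on the value of compound 3. Compound 4 is therefore estimated at 200000 nM, likely between 60000 nM and 600000 nM.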

Compound 4, half-maximal inhibitory concentration: 54300 nM
Compound 4: the middle estimate sits 3.7-fold (0.57 log units) above what was measured, and the stated range ends above it.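

In this assay, benzyl in place of phenyl on an amide-type nitrogen raised the number on the second core too, with a 2.0-fold higher number from compound 3 to compound 4 (0.31 log units; beyond the scatter), so the direction of the step held across these two cores. The size of the step did not carry over: the same change on two cores in this assay, an 11-fold higher number (1.02 log units; beyond the scatter) from compound 2 to compound 1 and a 2.0-fold higher number (0.31 log units; beyond the scatter) from compound 3 to compound 4, 5.2-fold (0.72 log units) apart, beyond the scatter of two such steps. These two pairs do not show which part of the difference between the cores governs that size, and they cannot say how the step would behave on a third core.

The compounds shown leave open how a longer chain, such as phenethyl, would behave on that nitrogen. Also open, as far as these compounds go, is how a benzyl group carrying an amine or a carboxylic acid would compare on either core.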